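This account rests on a few compounds, and the source may have more. Where it says the series, first, only, none or still open, it means among the compounds named here.

Compound 1 `COc1cc(Cl)cc(-c2nn(-c3cccc(NC(=O)Nc4ccc(Cl)c(C(F)(F)F)c4)c3)cc2-c2ccncc2)c1` gives 101% in a functional assay on HT-29 cells (Homo sapiens) for inhibition, read by sulforhodamine B assay, with a stated time of 48 h, tested at 0.01 uM; a lower number here means a stronger effect, a higher number a weaker effect of the compound at the concentration tested.
Compound 2 `COc1cc(Cl)cc(-c2nn(-c3cccc(NC(=O)Nc4cc(C(F)(F)F)cc(C(F)(F)F)c4)c3)cc2-c2ccncc2)c1` gives 102% in this assay.
Compound 3 `COc1cc(Cl)cc(-c2nn(-c3cccc(NC(=O)Nc4ccc(Cl)c(Cl)c4)c3)cc2-c2ccncc2)c1` gives 103% in this assay.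

Compound 3 holds the highest of the three numbers, with compound 2 nearest and compound 1 furthest, but both gaps lie within the scatter, so the three compounds cannot be set apart from one another. Compound 4 `COc1cc(Cl)cc(-c2nn(-c3cccc(NC(=O)Nc4cccc(C(F)(F)F)c4)c3)cc2-c2ccncc2)c1` differs from compound 3 in one place: 3-(trifluoromethyl)phenyl in place of 3,4-dichlorophenyl on an amide-type nitrogen. For the measured compounds named here, the one measured step that touches this part of the molecule is a number 2 percentage points higher from compound 1 to compound 3 (within the scatter), which stayed within the scatter; compound 2, carrying yet another group on the same nitrogen, sits with the others. Compound 4 is therefore expected to show no step beyond the scatter, a number 2 percentage points lower from compound 3 to compound 4 (within the scatter). The estimate for compound 4 in this assay is 101%, between 92% and 110%.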

Compound 4, a percentage reported as activity, at one concentration (the size of the read-out at that concentration, not a potency): 102%
Beside the measured number, compound 4's estimate is 1 percentage points below it; measured number inside the range.
By their numbers in this assay, from the lowest: compounds 1, 2, 4 and 3 (each within the scatter of the next).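

On the amide-type nitrogen, 3-(trifluoromethyl)phenyl proves interchangeable with 3,4-dichlorophenyl in this assay (a number 1 percentage points lower from compound 3 to compound 4 (within the scatter)). Hydrogen in place of one trifluoromethyl (no change at the digits printed from compound 2 to compound 4 (within the scatter)) or of the chloro (a number 1 percentage points higher from compound 1 to compound 4 (within the scatter)) also stays within the scatter, so a ring with a single substituent here cannot be told apart from those with two at this concentration. No available evidence bears on this result.

The compounds shown leave open whether any group on this ring would separate from these, such as an amine or a carboxylic acid in place of trifluoromethyl.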